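This account rests on a few compounds, and the source may have more. Where it says the series, first, only, none or still open, it means among the compounds named here.

Compounds measured in an assay on SH-EP1 cells for displacement of a labelled ligand from Neuronal acetylcholine receptor; alpha4/beta2 (Homo sapiens), read by scintillation counting (on this read-out lower numbers stand for stronger inhibition and higher numbers for weaker inhibition), so far:
- compound 1, `CCCC(=O)N1CC2CC(C1)N2`, gives 14 nM
- compound 2, `O=C(C1CCC1)N1CC2CC(C1)N2`, gives 16 nM
- compound 3, `C[C@@H]1C[C@H]1C(=O)N1CC2CC(C1)N2`, gives 1 nM

Compound 3 has the lowest number of the three, set apart by a 14-fold lower number from compound 1 to compound 3 (1.15 log units; beyond the scatter) and a 16-fold lower number from compound 2 to compound 3 (1.20 log units; beyond the scatter), while compound 1 and compound 2 sit within the scatter of each other (a 1.1-fold higher number from compound 1 to compound 2 (0.06 log units; within the scatter)).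

Compound 4, `C[C@H]1C[C@@H]1C(=O)N1CC2CC(C1)N2`, differs from compound 3 only in that (the two compounds have the same atoms and bonds; at least one stereo element is drawn with a configuration in one of them and without one in the other: 2 of 4 stereo elements differ; a stereocentre at a saturated ring carbon is drawn R in compound 3 and S in compound 4; a stereocentre at a saturated ring carbon is drawn R in compound 3 and S in compound 4). Among the compounds with values here, every measured step so far swaps the group on the carbonyl carbon; none changes a stereo element, so no measured step bears on this change. The direction and size of this change are therefore uncertain, and the step is estimated as a 5.0-fold higher number from compound 3 to compound 4 (0.70 log units; beyond the scatter), an estimate with a wide range. Compound 4 is expected near 5 nM, between 1 nM and 30 nM.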

Compound 4, inhibition constant: 17 nM
Compound 4: middle estimate off by 3.4-fold (0.53 log units), on the low side; measured number inside the range.
By their numbers in this assay, from the lowest: compound 3; then compounds 1, 2 and 4 (each within the scatter of the next).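

With atoms and bonds unchanged, the drawn configuration at the two saturated ring carbons alone carries a large step: a 17-fold higher number from compound 3 to compound 4 (1.23 log units; beyond the scatter). The 2-methylcyclopropyl group therefore does not give the low number in every drawn form, as the steps within the scatter show: a 1.1-fold higher number from compound 2 to compound 4 (0.03 log units; within the scatter) and a 1.2-fold higher number from compound 1 to compound 4 (0.08 log units; within the scatter). The stereo step needs this caution: the fact that one of compounds 3 and 4 is drawn with a defined configuration and the other without, at the place where they differ

Open, going by these compounds, is whether the low number depends on the methyl itself. An ethyl or a phenyl in its place on the cyclopropyl group could show whether compound 3 at 1 nM can be matched.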